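Extending the isopropyl group to sec-butyl

The compounds below may be only part of what the source reports. "The series", "measured", "known", "first", "only" and "open" are said of these compounds alone.

In a functional assay on PC-3 cells (Homo sapiens) for cytotoxicity, read by WST assay, with a stated time of 3 days (a higher number here means a weaker inhibitor, a lower number a stronger inhibitor), compound 1 `CCCn1ccnc1/C=C/C(=O)/C=C/c1coc2ccccc2c1=O` gives 2400 nM and compound 2 `CC(C)n1ccnc1/C=C/C(=O)/C=C/c1coc2ccccc2c1=O` gives 2300 nM. These two values lie within the scatter of each other, so compound 2 does not stand apart from compound 1. Compound 3 `CCC(C)n1ccnc1/C=C/C(=O)/C=C/c1coc2ccccc2c1=O` carries methyl in place of hydrogen on a saturated chain carbon, two bonds along the chain from an aromatic nitrogen, which turns isopropyl into sec-butyl: methyl in place of hydrogen on a saturated chain carbon, two bonds along the chain from an aromatic nitrogen. Within the data shown here, the one measured step at this chain, isopropyl in place of propyl on an aromatic nitrogen, is a 1.0-fold lower number from compound 1 to compound 2 (0.02 log units; within the scatter). Among the measured compounds shown here, that single step is thin evidence, and no measured compound carries sec-butyl. Even so, no shift beyond the scatter is expected in this assay. The expected change is a 1.0-fold lower number from compound 2 to compound 3 (0.02 log units; within the scatter). Compound 3 is estimated at 2200 nM, with an expected range of 1100 nM to 4500 nM.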

Compound 3, half-maximal inhibitory concentration: 1800 nM
For compound 3 the middle estimate is 1.2-fold (0.09 log units) above the measured one; low and high end bracket the measured number.
By their numbers in this assay, from the lowest: compounds 3, 2 and 1 (each within the scatter of the next).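

At this position, methyl in place of hydrogen on a saturated chain carbon, two bonds along the chain from an aromatic nitrogen, gives no shift beyond the scatter in this assay (a 1.3-fold lower number from compound 2 to compound 3 (0.11 log units; within the scatter)). The direct comparison of sec-butyl with propyl also stays within the scatter (a 1.3-fold lower number from compound 1 to compound 3 (0.12 log units; within the scatter)), so this read-out does not separate propyl, isopropyl and sec-butyl on the aromatic nitrogen, and the added methyl opens no trend. No supporting data bear on this result.

As far as these compounds go, whether a longer chain such as hexyl, or a ring such as cyclohexyl or phenyl, on the aromatic nitrogen would move the number beyond the scatter remains open. The same question stands for an amine or a carboxylic acid at the end of the chain.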